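The source may report more compounds than this note shows. Statements on the series, on what has been measured and on what is new or still open speak of the compounds shown alone.

Among the compounds with values here, compound 3 `COc1cc(-c2nn(-c3cccc(NC(=O)Nc4cccc(C(F)(F)F)c4)c3)cc2-c2ccncc2)ccc1Cl` is one of three compounds measured in a functional assay on CCRF-CEM cells (Homo sapiens) for inhibition, read by sulforhodamine B assay, with a stated time of 48 h; on this read-out higher numbers stand for weaker inhibition of growth and lower numbers for stronger inhibition of growth. In that assay compound 3 gives 945 nM, the second highest of the three numbers. Its nearest neighbour is compound 2 `O=C(Nc1cccc(-n2cc(-c3ccncc3)c(-c3ccc(Cl)c(O)c3)n2)c1)Nc1cc(C(F)(F)F)cc(C(F)(F)F)c1`, which in this assay gives 789 nM; the furthest is compound 1 `COc1cc(-c2nn(-c3cccc(NC(=O)c4ccc(Cl)c(C(F)(F)F)c4)c3)cc2-c2ccncc2)ccc1Cl`, which gives 1770 nM. Within the data shown here, both gaps lie within the scatter, as does the single one-place step among them, a 1.9-fold lower number from compound 1 to compound 3 (0.27 log units; within the scatter).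

Compound 4 `COc1cc(-c2nn(-c3cccc(NC(=O)Nc4cc(C(F)(F)F)cc(C(F)(F)F)c4)c3)cc2-c2ccncc2)ccc1Cl` has not yet been measured. It differs from compound 3 in one place: trifluoromethyl in place of hydrogen on an aromatic carbon. Among the measured compounds shown here, no measured step covers exactly this change. Compound 2, however, already carries two trifluoromethyl groups on a six-membered aromatic ring of carbon only and gives 789 nM, a number within the scatter of compound 3 at 945 nM. On that basis the step is expected to stay within the scatter, a 1.2-fold lower number from compound 3 to compound 4 (0.07 log units; within the scatter). Compound 4 is therefore estimated at 800 nM, with a range from 350 nM to 1900 nM.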

Compound 4, concentration for 50% growth inhibition: 498 nM
Estimate against measurement, compound 4: 1.6-fold (0.21 log units) above, within the range that was stated.
By their numbers in this assay, from the lowest: compounds 4, 2, 3 and 1 (each within the scatter of the next, the first and the last beyond it).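

In this assay, a second trifluoromethyl on the six-membered aromatic ring of carbon only, meta to the first trifluoromethyl group, gives a 1.9-fold lower number from compound 3 to compound 4 (0.28 log units; within the scatter), so this position takes the group without a step beyond the scatter. Within the data shown here, the change on the oxygen, which no earlier pair could read, gives a 1.6-fold lower number from compound 2 to compound 4 (0.20 log units; within the scatter), so methyl in place of hydrogen there also stays within the scatter in the presence of the two trifluoromethyl groups. No measurement is at hand that would explain either step.

The compounds shown leave open whether a nitrile, an amine or a carboxylic acid at this aromatic carbon would also stay within the scatter of compound 3. They also leave open what an ethyl group or a longer chain on the oxygen would give.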